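Adding a Chloro Group Next in Line after Trifluoromethyl

A few compounds are considered here, and "the series" means these few. Any claim that something is new, unique, unknown or untested is made for them only; others in the source may bear on it.

The three measured compounds share one core and differ only in the substituent pattern of the phenyl ring on the urea. Compound 1 `O=C(Nc1ccccc1)Nc1nnc(Sc2ncnc3scc(-c4ccncc4)c23)s1` gives 19400 nM in a functional assay on HepG2 cells (Homo sapiens) for antiproliferative activity, read by MTT assay, with a stated time of 48 h; a higher number here means a weaker inhibitor, a lower number a stronger inhibitor. Compound 2 `O=C(Nc1cccc(C(F)(F)F)c1)Nc1nnc(Sc2ncnc3scc(-c4ccncc4)c23)s1` gives 15300 nM, the lowest of the three numbers, though a 1.3-fold lower number from compound 1 to compound 2 (0.10 log units; within the scatter) stays within the scatter. Compound 3 `Cc1ccc(NC(=O)Nc2nnc(Sc3ncnc4scc(-c5ccncc5)c34)s2)cc1` gives 52000 nM; a 2.7-fold higher number from compound 1 to compound 3 (0.43 log units; beyond the scatter) and a 3.4-fold higher number from compound 2 to compound 3 (0.53 log units; beyond the scatter) are both modest steps toward weaker inhibition.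

Compound 4 `O=C(Nc1ccc(Cl)c(C(F)(F)F)c1)Nc1nnc(Sc2ncnc3scc(-c4ccncc4)c23)s1` is obtained from compound 2 by chloro in place of hydrogen on an aromatic carbon, the chloro entering ortho to the trifluoromethyl group and para to a large group. Among the compounds with values here, the only step that adds a small group at that para position is that of compound 3, which weakened inhibition; the trifluoromethyl addition in compound 2 changed little. On that basis a small shift toward a higher number, or none beyond the scatter, is expected: a 1.2-fold higher number from compound 2 to compound 4 (0.09 log units; within the scatter). Compound 4 is estimated at 19000 nM, in the range 7000 nM to 50000 nM.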

Compound 4, half-maximal inhibitory concentration: 45300 nM
Compound 4: middle estimate off by 2.4-fold (0.38 log units), on the low side; the range from low to high includes it.
By their numbers in this assay, from the lowest: compounds 2 and 1 (each within the scatter of the next); then compounds 4 and 3 (each within the scatter of the next).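

With the trifluoromethyl group in place, chloro para to a large group does not leave the number unchanged in this assay as a 3.0-fold higher number from compound 2 to compound 4 (0.47 log units; beyond the scatter) shows, so the low number of compound 2 does not survive substitution at this position. The 4-chloro-3-(trifluoromethyl)phenyl group also falls on the weaker side of the plain phenyl group with a 2.3-fold higher number from compound 1 to compound 4 (0.37 log units; beyond the scatter) as the step, while a 1.1-fold lower number from compound 3 to compound 4 (0.06 log units; within the scatter) places it level with the 4-methylphenyl group, so methyl and chloro at this position, the only two groups shown there, give matching numbers. Nothing available bears on why this position responds this way.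

The compounds shown leave open whether an amine or a carboxylic acid para to a large group would give the same weaker numbers. They also leave open whether chloro has the same effect on a phenyl ring without the trifluoromethyl group.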